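The source may hold more compounds than are shown below. What is called first, only, known or untested is meant among the compounds shown, and "the series" means these compounds.

Compound 1, with the structure `CC(=O)c1ccc(/C=C2\CCCN=C2c2cccnc2)cc1`, is one of three compounds tested in an assay on membranes from brain for displacement of a labelled ligand from Neuronal acetylcholine receptor; alpha4/beta2 (Rattus norvegicus), with a stated time of 3 h; on this read-out higher numbers stand for weaker inhibition and lower numbers for stronger inhibition. In that test compound 1 gives 4490 nM. Compound 2, `CC(C)(C)C(=O)Oc1ccccc1/C=C1\CCCN=C1c1cccnc1`, gives 1440 nM, and compound 3, `Oc1cccc(/C=C2\CCCN=C2c2cccnc2)c1`, gives 1170 nM. Compound 1 therefore stands highest of the three, that is, it is the weakest binder in this assay, and its distance to each of the other two goes beyond the usual scatter of such measurements.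

Compound 4, `CC(C)(C)Oc1ccc(/C=C2\CCCN=C2c2cccnc2)cc1`, has not yet been measured. It differs from compound 1 in one place: tert-butoxy in place of acetyl on an aromatic carbon. Both groups sit on the same aromatic carbon, and both carry one hydrogen-bond acceptor, so the change is chiefly one of shape and size. Going by the values given here, no measured pair shows this exact change, so nothing tells how large its effect will be. Given that every other variation at the aromatic ring gave a lower number than compound 1, a modest step down is expected, though one that may stay within the scatter. Compound 4 is estimated at 2800 nM, between 900 nM and 9000 nM, an expected change of a 1.6-fold lower number from compound 1 to compound 4 (0.21 log units; within the scatter) from compound 1.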

Compound 4, inhibition constant: 2170 nM
Compound 4: middle estimate off by 1.3-fold (0.11 log units), on the high side, within the range that was stated.
By their numbers in this assay, from the lowest: compounds 3, 2 and 4 (each within the scatter of the next); then compound 1.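

In this assay, going by these compounds alone, putting tert-butoxy in place of acetyl on this aromatic carbon, para to a large group, gives a 2.1-fold lower number from compound 1 to compound 4 (0.32 log units; beyond the scatter) as the first step in this set that can be traced to a change in one place. At this carbon, then, a group of 5 heavy atoms can replace one of 3 without weakening binding, and the number moves modestly lower even though both groups carry one hydrogen-bond acceptor. No measurement here explains why the number moves.

As far as these compounds go, whether a methoxy group, an amine or a carboxylic acid on this same carbon would push the number further down or back up remains open. It is also unknown whether the same exchange would give a step of similar size on another aromatic carbon.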